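Hydrogen for methyl on the chloro compound

A few compounds are considered here, and "the series" means these few. Any claim that something is new, unique, unknown or untested is made for them only; others in the source may bear on it.

In a functional assay on A549 cells (Homo sapiens) for cytotoxicity, read by MTT assay, with a stated time of 72 h (on this read-out lower numbers stand for stronger inhibition and higher numbers for weaker inhibition), compound 1 `Cn1ccc2c(Oc3ccc(NC(=O)c4cc5cccnc5n(-c5ccc(F)cc5)c4=O)cc3F)ncnc21` gives 7320 nM and compound 2 `Cn1ccc2c(Oc3ccc(NC(=O)c4cc5cccnc5n(-c5ccc(Cl)cc5)c4=O)cc3F)ncnc21` gives 55500 nM, the higher of the two numbers. Going by the values given here, the only measured step is a 7.6-fold higher number from compound 1 to compound 2 (0.88 log units; beyond the scatter), for chloro in place of fluoro on an aromatic carbon. Next comes compound 3 `O=C(Nc1ccc(Oc2ncnc3[nH]ccc23)c(F)c1)c1cc2cccnc2n(-c2ccc(Cl)cc2)c1=O`, with hydrogen in place of methyl on an aromatic nitrogen. Among the compounds with values here, no measured step touches that nitrogen, so the halogen step serves only as a rough gauge of how far one small change can move the numbers in this assay. A step of similar or smaller size is expected, leaning towards a lower number, as compound 2 at 55500 nM already stands at the high end of what has been seen. The estimate for compound 3 is 22000 nM, with an expected range of 5000 nM to 80000 nM. That amounts to an estimated 2.5-fold lower number from compound 2 to compound 3 (0.40 log units; beyond the scatter).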

Compound 3, half-maximal inhibitory concentration: 35500 nM
For compound 3 the middle estimate is 1.6-fold (0.21 log units) below the measured one; measured number inside the range.
By their numbers in this assay, from the lowest: compound 1; then compounds 3 and 2 (each within the scatter of the next).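

In this assay, hydrogen in place of methyl on the aromatic nitrogen of the five-membered aromatic ring gives a 1.6-fold lower number from compound 2 to compound 3 (0.19 log units; within the scatter) and so stays within the scatter on the chloro compound. Going by these compounds alone, this is the first reading at this nitrogen, and here the methyl can give way to hydrogen with no difference that can be told from repeat measurements, unlike the halogen exchange of a 7.6-fold higher number from compound 1 to compound 2 (0.88 log units; beyond the scatter) on the aromatic carbon. The data available offer no explanation for either result.

Still open, as far as these compounds go, is whether the fluoro compound responds in the same way to hydrogen on that nitrogen. Also open, from the compounds shown here alone, is whether a longer chain, or a chain ending in an amine, at the same nitrogen would remain within the scatter.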